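A few compounds are considered here, and "the series" means these few. Any claim that something is new, unique, unknown or untested is made for them only; others in the source may bear on it.

Measured compounds and their values:

Compound 1, `CCc1ccc(N(CC(C)C)S(=O)(=O)c2ccc3c(c2)C(=O)N(C2CCOCC2)C3)cc1`, gives 3.64 in a physicochemical assay for lipophilicity, at pH 7.4; a lower number here means a more polar compound, a higher number a more lipophilic compound.
Compound 2, `CC(C)CN(c1ccc(N(C)C)cc1)S(=O)(=O)c1ccc2c(c1)C(=O)CC(C1CCOCC1)O2`, gives 3.6 in this assay.
Compound 3, `CC(C)CN(c1ccc(F)cc1)S(=O)(=O)c1ccc2c(c1)C(=O)CC(C1CCOCC1)O2`, gives 3.48 in this assay.

Compound 3 has the lowest of the three numbers, but its gaps to the other two are small: compound 2 sits a number 0.12 log units lower from compound 2 to compound 3 (within the scatter) away, and compound 1 differs from compound 3 by an amount that is also within the scatter. The three measured compounds therefore sit at much the same level of lipophilicity.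

The step to the unmeasured compound 4, `CC(C)CN(c1ccc(C#N)cc1)S(=O)(=O)c1ccc2c(c1)C(=O)CC(C1CCOCC1)O2`, is cyano in place of fluoro on an aromatic carbon. Within the data shown here, only one measured step touches the same position on the ring: the move from dimethylamino to fluoro, a number 0.12 log units lower from compound 2 to compound 3 (within the scatter), which gave no change beyond the scatter. Among the measured compounds shown here, no measured pair swaps fluoro for cyano, so the data give no direct guide for this change. The change adds one hydrogen-bond acceptor and one more heavy atom than it removes, and on that basis a drop in this assay is expected, somewhat larger than the scatter. For compound 4 the estimate is 2.9, with a range from 2.5 to 3.3. This estimate corresponds to an expected step of a number 0.58 log units lower from compound 3 to compound 4 (beyond the scatter).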

Compound 4, distribution coefficient: 3.16
Compound 4: the middle estimate sits 0.26 log units below what was measured, and the stated range covers the measured number.
By their numbers in this assay, from the lowest: compound 4; then compounds 3, 2 and 1 (each within the scatter of the next).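

In this assay, cyano in place of fluoro on this aromatic carbon gives a number 0.32 log units lower from compound 3 to compound 4 (beyond the scatter) and is the first change at this position shown to move the number past the usual spread of repeats. Cyano in place of dimethylamino on the same carbon gives a number 0.44 log units lower from compound 2 to compound 4 (beyond the scatter) while fluoro in place of dimethylamino gives only a number 0.12 log units lower from compound 2 to compound 3 (within the scatter) so of the three groups compared here, para to a large group on the same core, cyano alone stands apart, with dimethylamino and fluoro at much the same level. Nothing measured here accounts for the shift seen with cyano.

Going by these compounds, with only these three groups at this carbon, it remains open whether a carboxylic acid, a primary amine or a methoxy group would stay level with fluoro or fall as far as cyano or further. Among these compounds, it is also open whether the same swap from 4-fluorophenyl to 4-cyanophenyl would give a step of similar size on a different core, such as the one in compound 1.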